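Thiocarbamate Tail in Place of a Fluorinated Carbamate

The source may report more compounds than this note shows. Statements on the series, on what has been measured and on what is new or still open speak of the compounds shown alone.

Within the data shown here, compound 2 `Cc1nc(S(C)(=O)=O)ccc1Oc1ncnc(OC2CCN(C(=O)O[C@H](C)CF)CC2)c1F` gives 1520 nM in a functional assay on isolated protein for inhibition of Glucose-dependent insulinotropic receptor (Rattus norvegicus), read by HTRF and cAMP accumulation (a higher number here means that more compound is needed for the effect, a lower number that less compound is needed), the highest of the three numbers measured so far. Compound 1 `Cc1nc(S(C)(=O)=O)ccc1Oc1ncnc(OC2CCN(C(=O)OC(C)C)CC2)c1F` gives 142 nM and compound 3 `CCC1(OC(=O)N2CCC(Oc3ncnc(Oc4ccc(S(C)(=O)=O)nc4C)c3F)CC2)CC1` gives 333 nM. The step of an 11-fold higher number from compound 1 to compound 2 (1.03 log units; beyond the scatter) is large, while a 4.6-fold lower number from compound 2 to compound 3 (0.66 log units; beyond the scatter) is modest. Compound 4 `Cc1nc(S(C)(=O)=O)ccc1Oc1ncnc(OC2CCN(C(=O)SC3CC3)CC2)c1F` differs from compound 2 as follows: a group of 4 heavy atoms (3 carbon, 1 sulfur; one three-membered non-aromatic ring of carbon only) in place of a group of 5 heavy atoms (3 carbon, 1 oxygen, 1 fluorine; no ring), on a carbonyl carbon. Both measured steps that touch compound 2 bear on this change: the fluorine that entered in an 11-fold higher number from compound 1 to compound 2 (1.03 log units; beyond the scatter) leaves again, and a tail without fluorine gave a 4.6-fold lower number from compound 2 to compound 3 (0.66 log units; beyond the scatter). A lower number is therefore expected for compound 4, of modest to large size, a 5.1-fold lower number from compound 2 to compound 4 (0.70 log units; beyond the scatter). Compound 4 is estimated at 300 nM, with a range from 80 nM to 1200 nM.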

Compound 4, half-maximal effective concentration: 126 nM
Estimate against measurement, compound 4: 2.4-fold (0.38 log units) above; low and high end bracket the measured number.
By their numbers in this assay, from the lowest: compounds 4 and 1 (each within the scatter of the next); then compound 3; then compound 2.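

In this assay, among these compounds, the thiocarbamate tail of compound 4 is the first ring-bearing tail to match the isopropyl tail, with a 1.1-fold lower number from compound 1 to compound 4 (0.05 log units; within the scatter). Tails carrying a three-membered carbon ring are not all alike at this carbonyl carbon, as shown by a 2.6-fold lower number from compound 3 to compound 4 (0.42 log units; beyond the scatter), and replacing the fluorinated tail gives a 12-fold lower number from compound 2 to compound 4 (1.08 log units; beyond the scatter). Nothing available explains these differences. Sulfur and the ring entered together, so the compounds shown do not separate their contributions. An isopropyl group on the sulfur would leave that question less open.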